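From benzamido to isopropoxy at the assay limit

This account rests on a few compounds, and the source may have more. Where it says the series, first, only, none or still open, it means among the compounds named here.

Compound 1 `COc1ccc(C2=C(c3cc(OC)c(OC)c(OC)c3)C(=O)CC2O[SiH2]C(C)(C)C)cc1` gives > 100 ug/mL as a limit
Compound 2 `COc1ccc(C2=C(c3cc(OC)c(OC)c(OC)c3)C(=O)C(O)C2)cc1NC(=O)c1ccccc1` gives > 100 ug/mL as a limit
Compound 3 `COc1ccc(C2=C(c3cc(OC)c(OC)c(OC)c3)C(=O)CC2O)cc1` gives > 100 ug/mL as a limit

In an ADME assay on MIA PaCa-2 cells (Homo sapiens) for cytotoxicity, read by MTT assay, with a stated time of 72 h (on this read-out higher numbers stand for weaker inhibition and lower numbers for stronger inhibition), compound 2 stands at > 100 ug/mL as a limit of the assay and not a number. The two other measured compounds also report only limits, so compound 2 offers no number from which to count. The change to compound 4 `COc1ccc(C2=C(c3cc(OC)c(OC)c(OC)c3)C(=O)C(O)C2)cc1OC(C)C` is isopropoxy in place of benzamido on an aromatic carbon, which is isopropoxy in place of benzamido on an aromatic carbon, ortho to a methoxy group. Going by the values given here, the only measured step, a step that the two limits leave unreadable from compound 1 to compound 3, lies on an oxygen on a saturated carbon, not at this place, and its size cannot be read. It therefore gives no size to carry over. Among the compounds with values here, what remains is the limit of > 100 ug/mL in this assay, at which 3 of the 3 values shown sit, as the only guide. Within the data shown here, no step of known size or direction is expected in this assay beyond the scatter, and compound 4 is expected most likely to report a limit again. The estimated step is a number no higher from compound 2 to compound 4 (the limit leaves the size open) and it rests on that limit alone. For compound 4 the estimate is 100 ug/mL, with an expected range from 40 ug/mL to 200 ug/mL if a number is reported at all.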

Compound 4, half-maximal inhibitory concentration: > 100 ug/mL
Compound 4: a limit, no number; the forecaster's own chance of this, stated with the estimate: 70%; the middle value sits exactly at the limit.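

Compound 2 and compound 4 both report only a limit of the assay, so replacing benzamido with isopropoxy gives no readable step between them. The compounds shown leave open how they rank in this assay and what either group does to the read-out, since the only guide is a single one: the limit of > 100 ug/mL in this assay, at which 4 of the 4 values shown sit.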